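A few compounds are considered here, and "the series" means these few. Any claim that something is new, unique, unknown or untested is made for them only; others in the source may bear on it.

Values in a functional assay on Jurkat cells (Homo sapiens) for inhibition, read by MTT assay, with a stated time of 72 h; on this read-out higher numbers stand for weaker inhibition and lower numbers for stronger inhibition:
- Compound 1 `C=C(Br)C(=O)Nc1cccc(/C=C/C(=O)Nc2ccc(F)cc2)c1`: 6200 nM
- Compound 2 `C=C(Br)C(=O)Nc1cccc(/C=C/C(=O)Nc2ccc(Cl)cc2)c1`: 2600 nM
- Compound 3 `C=C(Br)C(=O)Nc1cccc(/C=C/C(=O)Nc2ccc(C)cc2)c1`: 240 nM

Compound 3 has the lowest number of the three. Compound 2 is its nearest neighbour, an 11-fold lower number from compound 2 to compound 3 (1.03 log units; beyond the scatter), and compound 1 lies furthest away, a 26-fold lower number from compound 1 to compound 3 (1.41 log units; beyond the scatter).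

Compound 4 `C=C(Br)C(=O)Nc1cccc(/C=C/C(=O)Nc2ccc(OCC)cc2)c1` keeps the shared core and differs from compound 3 at one place: ethoxy in place of methyl on an aromatic carbon. This puts ethoxy in place of methyl on an aromatic carbon, para to a large group.

All three measured steps bear on this change, since each is a swap at that same place. The step of a 2.4-fold lower number from compound 1 to compound 2 (0.38 log units; beyond the scatter) is modest, while the steps of a 26-fold lower number from compound 1 to compound 3 (1.41 log units; beyond the scatter) and an 11-fold lower number from compound 2 to compound 3 (1.03 log units; beyond the scatter) are large. Among the compounds with values here, the number therefore clearly responds to the group at this place, but no measured compound carries ethoxy there, so the direction is uncertain. With compound 3 at 240 nM, the lowest of the series, a modest move to a higher number in this assay is expected, and a large step in either direction cannot be excluded. The expected change is a 2.5-fold higher number from compound 3 to compound 4 (0.40 log units; beyond the scatter). Compound 4 is estimated at 600 nM, with an expected range of 120 nM to 2500 nM.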

Compound 4, half-maximal inhibitory concentration: 930 nM
For compound 4 the middle estimate is 1.6-fold (0.19 log units) below the measured one; low and high end bracket the measured number.
By their numbers in this assay, from the lowest: compound 3; then compound 4; then compound 2; then compound 1.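

In this assay, ethoxy does not rank with methyl or with either halogen but falls between them, with a 3.9-fold higher number from compound 3 to compound 4 (0.59 log units; beyond the scatter) on one side and, on the other, a 2.8-fold lower number from compound 2 to compound 4 (0.45 log units; beyond the scatter) and a 6.7-fold lower number from compound 1 to compound 4 (0.82 log units; beyond the scatter). Until now the series had shown only single-atom or one-carbon groups at this place on the aromatic ring, so compound 4 is the first evidence that it accepts a substituent of 3 heavy atoms, including an oxygen and 1 hydrogen-bond acceptor, while keeping a lower number than both halogen compounds; methyl nevertheless remains the best group of the four, and the larger ethoxy does not improve on it. Nothing available here explains this order of the four groups.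

The compounds shown cannot separate the contribution of the oxygen from that of the added carbon, a question that methoxy and ethyl at the same place could address. They also leave open how the number would respond to a longer chain such as propoxy or butyl, to a hydroxyl, or to an amine.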